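The source may report more compounds than this note shows. Statements on the series, on what has been measured and on what is new or still open speak of the compounds shown alone.

Measured compounds and their values in a functional assay on A549 cells (Homo sapiens) for cytotoxicity, read by sulforhodamine B assay, with a stated time of 48 h, tested at 0.01 uM; on this read-out higher numbers stand for a weaker effect at the one concentration tested and lower numbers for a stronger effect:

compound 1, `COc1cc(-c2cc(/C=C/C(=O)c3ccc(N)cc3)[nH]n2)cc(OC)c1OC`, gives 96%
compound 2, `COc1ccc(-c2cc(/C=C/C(=O)c3ccc(N)cc3)[nH]n2)cc1OC`, gives 97%
compound 3, `COc1ccc(-c2cc(/C=C/C(=O)c3cc(OC)c(OC)c(OC)c3)[nH]n2)cc1OC`, gives 101%

All three numbers sit close to one another, so compound 1 has the lowest value of the three only in a formal sense: compound 2 is a step of a number 1 percentage points higher from compound 1 to compound 2 (within the scatter) away, and the gap to compound 3 is also within the scatter. In plain terms, none of the three compounds shows an effect on the cells at this concentration that can be told apart from the others.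

Compound 4, `COc1ccc(C(=O)/C=C/c2cc(-c3cc(OC)c(OC)c(OC)c3)n[nH]2)cc1`, is not yet measured. It differs from compound 1 by a single change: methoxy in place of amino on an aromatic carbon.

Going by the values given here, the only measured step that replaces a group on the same kind of aromatic carbon is the one from compound 1 to compound 2, and it stayed within the scatter. That step exchanges a different pair of groups, so it bears on the present change only loosely. With all three measured compounds sitting near the same level, no step beyond the scatter is expected in this assay, in either direction. The estimated step from compound 1 to compound 4 is therefore a number 2 percentage points higher from compound 1 to compound 4 (within the scatter), and compound 4 is expected to give 98%, within a range from 88% to 108%.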

Compound 4, a percentage reported as activity, at one concentration (the size of the read-out at that concentration, not a potency): 98%
The estimate for compound 4 equals the measured number at the digits printed, and the stated range covers the measured number.
By their numbers in this assay, from the lowest: compounds 1, 2, 4 and 3 (each within the scatter of the next).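

Compound 4 brings the first change shown on the 4-aminophenyl end of the molecule, since the earlier single-place step between compound 1 and compound 2 lay elsewhere. In this assay, replacing amino with methoxy at this position, on an aromatic carbon para to a large group, gives a step of a number 2 percentage points higher from compound 1 to compound 4 (within the scatter), so at this one concentration the read-out does not separate the two groups, even though the count of hydrogen-bond donors in this group goes from one to none. No measurement at hand explains this result.

The read-out comes from a single concentration at which all the compounds shown sit at much the same level, so it cannot tell whether amino and methoxy would differ under conditions where the cells respond more clearly. From the compounds shown here alone, it also remains open whether a carboxylic acid, a fluorine atom or a longer chain such as butoxy at the same position would move the number beyond the scatter.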